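Bromo for Chloro: An Expected Small Step

The source may report more compounds than this note shows. Statements on the series, on what has been measured and on what is new or still open speak of the compounds shown alone.

Measured so far in an assay on isolated protein for inhibition of alpha-ketoglutarate-dependent dioxygenase alkB homolog 3 (Homo sapiens), read by polymerase chain reaction, with a stated time of 1 h; on this read-out higher numbers stand for weaker inhibition and lower numbers for stronger inhibition:
compound 1 `Oc1c(-c2ccccc2)c(-c2ccccc2)nn1-c1nc2cc(Cl)ccc2[nH]1`, 2000 nM
compound 2 `Cc1[nH]n(-c2nc3cc(Cl)ccc3[nH]2)c(=O)c1Cc1ccccc1`, 4500 nM
compound 3 `Cc1c(-c2ccccc2)[nH]n(-c2nc3ccccc3[nH]2)c1=O`, > 10000 nM

Of the two numbers, compound 2 holds the higher one. Compound 1 gives the lower number, and the gap between the two lies beyond the usual scatter. For compound 3 the value is a limit rather than a number; it is the limit of > 10000 nM in this assay, at which 1 of the 3 values shown sits.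

Compound 4 `Cc1[nH]n(-c2nc3cc(Br)ccc3[nH]2)c(=O)c1Cc1ccccc1` is not yet measured. It differs from compound 2 by bromo in place of chloro on an aromatic carbon. Among the compounds with values here, no measured pair shows the effect of such an exchange, so the step from compound 2 to compound 4 is expected to be small, in no fixed direction, and likely within the scatter. Compound 4 is therefore estimated at 4000 nM, between 1500 nM and 11000 nM, a step of a 1.1-fold lower number from compound 2 to compound 4 (0.05 log units; within the scatter).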

Compound 4, half-maximal inhibitory concentration: 490 nM
Compound 4: the middle estimate sits 8.2-fold (0.91 log units) above what was measured; measured number outside the range, below it.
By their numbers in this assay, from the lowest: compound 4; then compound 1; then compound 2. At a limit, above all of these: compound 3.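

In this assay bromo in place of chloro on this aromatic carbon gives a 9.2-fold lower number from compound 2 to compound 4 (0.96 log units; beyond the scatter) and thereby shows that the read-out is sensitive to which halogen sits at this place. Within the data shown here, no earlier pair tested this position, and the finding rests on this one exchange. Nothing measured here accounts for the size of the step. From the compounds shown here alone, whether fluoro, iodo, an amine or a methoxy group at this carbon would give a lower or a higher number stays open. So does whether bromo in place of chloro gives a similar step on the core of compound 1.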